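The source may hold more compounds than are shown below. What is called first, only, known or untested is meant among the compounds shown, and "the series" means these compounds.

Working notes on the series in an ADME assay on cells (Hepatocyte, Mus musculus) for metabolic stability; a higher number here means that the compound lasts longer, a lower number that the compound disappears faster. Compound 1 `O=c1cc(N2CCN(CC3CCC(NS(=O)(=O)c4ccccc4)CC3)CC2)sc2c([N+](=O)[O-])cc(C(F)(F)F)cc12` reads > 1.55 h, which is a limit of the assay. Compound 2 `CC(=O)OC1CCC(CN2CCN(c3cc(=O)c4cc(C(F)(F)F)cc([N+](=O)[O-])c4s3)CC2)CC1` reads < 0.15 h, also a limit. Among the compounds with values here, compound 3 `O=C(OC1CCC(CN2CCN(c3cc(=O)c4cc(C(F)(F)F)cc([N+](=O)[O-])c4s3)CC2)CC1)c1ccc(C(F)(F)F)cc1` gives 0.278 h, the only actual number so far. Compound 4 `O=C(OC1CCC(CN2CCN(c3cc(=O)c4cc(C(F)(F)F)cc([N+](=O)[O-])c4s3)CC2)CC1)C1CCCCC1` differs from it as follows: cyclohexyl in place of 4-(trifluoromethyl)phenyl on a carbonyl carbon. The closest measured change, on the same carbonyl carbon, is an at least 1.8-fold higher number from compound 2 to compound 3 (0.26 log units; that floor lies within the scatter), and its floor lies within the scatter. The large at least 10-fold lower number from compound 1 to compound 2 (1.01 log units; beyond the scatter) replaces (phenylsulfonyl)amino on a saturated ring carbon, so it bears only loosely on this swap. Neither step sets a direction, so nothing beyond the scatter is expected. The expected change is a 1.3-fold lower number from compound 3 to compound 4 (0.10 log units; within the scatter). Compound 4 is estimated at 0.22 h, with an expected range of 0.1 h to 0.5 h.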

Compound 4, half-life: 0.0783 h
The estimate for compound 4 lay 2.8-fold (0.45 log units) above the measured number; measured number outside the range, below it.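

Within the data shown here, on the carbonyl carbon, the ring itself matters in this assay: cyclohexyl in place of 4-(trifluoromethyl)phenyl gives a 3.6-fold lower number from compound 3 to compound 4 (0.55 log units; beyond the scatter), the first change at this position that reads beyond the scatter. Swapping (phenylsulfonyl)amino for (cyclohexylcarbonyl)oxy on the saturated ring carbon gives an at least 19-fold lower number from compound 1 to compound 4 (1.29 log units; beyond the scatter), a step whose floor rests on the limit of compound 1: the limit of > 1.55 h in this assay, at which 1 of the 4 values shown sits. The step from compound 2 to compound 4 cannot be read, as compound 2 stands at a limit: the limit of < 0.15 h in this assay, at which 1 of the 4 values shown sits.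

The compounds shown do not separate the aromatic ring from its trifluoromethyl. A plain phenyl on this carbonyl carbon would bear on that.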